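This account rests on a few compounds, and the source may have more. Where it says the series, first, only, none or still open, it means among the compounds named here.

In a functional assay on cells (Platelet, Homo sapiens) for inhibition (on this read-out higher numbers stand for weaker inhibition and lower numbers for stronger inhibition), compound 1 (`CCOC(=O)c1ccc(-c2nn(Cc3ccccc3Cl)c3ccccc23)cc1`) gives > 10000 nM as a limit of the assay, not a number. Compound 2 (`CCOC(=O)c1ccc(-c2nn(-c3ccoc3)c3ccccc23)cc1`) gives > 10000 nM as a limit too. Within the data shown here, compound 2 therefore stands without a number, and the only other value shown is also a limit (the limit of > 10000 nM in this assay, at which 2 of the 2 values shown sit). Compound 3 (`CCOC(=O)c1ccc(-c2nn(CC)c3ccccc23)cc1`) carries ethyl in place of furan-3-yl on an aromatic nitrogen. Among the measured compounds shown here, the one measured step at this place is a step that the two limits leave unreadable from compound 1 to compound 2 and gives no readable size or direction. Neither limit shows any inhibition as a number, so no step beyond the scatter is expected in this assay, and a further limit is the likeliest report. For compound 3 the estimate is 12000 nM with an expected range from 4000 nM to 30000 nM as the likely span. The estimated step is a step that the limit leaves unreadable from compound 2 to compound 3 in this reading.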

Compound 3, half-maximal inhibitory concentration: > 10000 nM
Compound 3 ended at the assay's limit; the forecaster's own chance of this, stated with the estimate: 85%; the middle value does not contradict the limit.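

In this assay compound 3 also ends at a limit and not a number, so no step among compound 1, compound 2 and compound 3 can be read: the limit of > 10000 nM in this assay, at which 3 of the 3 values shown sit.

The compounds shown leave open whether any group on this aromatic nitrogen gives inhibition that can be put as a number.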